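The source may report more compounds than this note shows. Statements on the series, on what has been measured and on what is new or still open speak of the compounds shown alone.

Measured compounds:
Compound 1, `Cc1cc(C)c2c(C#N)cn(-c3ccc(C(C)C)cc3Br)c2n1`, gives 363 nM in an assay on isolated protein for binding affinity to corticotropin-releasing factor receptor 1 (Rattus norvegicus); a lower number here means a stronger inhibitor, a higher number a weaker inhibitor.
Compound 2, `Cc1cc(C)c2ccn(-c3ccc(C(C)C)cc3Br)c2n1`, gives 47 nM in this assay.
Compound 3, `Cc1cc(Cl)nc2c1ccn2-c1ccc(C(C)C)cc1Br`, gives 79 nM in this assay.

Compound 2 has the lowest number of the three. Its gap to compound 3, a 1.7-fold higher number from compound 2 to compound 3 (0.23 log units; within the scatter), lies within the scatter, so the two cannot be ranked against each other. Its gap to compound 1 is larger: the change from compound 1 to compound 2, hydrogen in place of cyano on an aromatic carbon, brought a 7.7-fold lower number from compound 1 to compound 2 (0.89 log units; beyond the scatter).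

Compound 4, `Cc1cc(C)c2c(C(N)=O)cn(-c3ccc(C(C)C)cc3Br)c2n1`, is not yet measured. It differs from compound 2 by carbamoyl in place of hydrogen on an aromatic carbon. This is the same position that carried the cyano group in compound 1, and there the presence of a group instead of hydrogen went with a clearly higher number. Going by the values given here, only that one step bears on the question, and the carbamoyl is a different group from cyano, so the expectation rests on a single comparison. In this assay compound 4 is therefore expected to show a higher number than compound 2, by about a 5.3-fold higher number from compound 2 to compound 4 (0.73 log units; beyond the scatter), most likely beyond the scatter. The estimate for compound 4 is 250 nM, with a likely range from 80 nM to 800 nM.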

Compound 4, inhibition constant: > 10000 nM
Compound 4: no number, only a limit; the forecaster's own chance of this, stated with the estimate: 5%; at least 40-fold (1.60 log units) between middle value and limit.
By their numbers in this assay, from the lowest: compounds 2 and 3 (each within the scatter of the next); then compound 1. At a limit, above all of these: compound 4.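

Compound 4 gives no number in this assay, only a limit of the assay: the limit of > 10000 nM in this assay, at which 1 of the 4 values shown sits. Carbamoyl in place of hydrogen on this aromatic carbon of the five-membered ring brings an at least 210-fold higher number from compound 2 to compound 4 (2.32 log units; beyond the scatter) and so costs far more than compound 1 alone suggested. The identity of the group also matters, not just the presence of one: carbamoyl in place of cyano brings an at least 27-fold higher number from compound 1 to compound 4 (1.44 log units; beyond the scatter) on the same carbon, so these two groups cannot be treated as interchangeable here.

The compounds shown cover only hydrogen, cyano and carbamoyl at this carbon, so the outcome with methyl, an amine or a carboxylic acid remains open. They also leave open whether carbamoyl would give the same result on the core of compound 3, which carries chloro in place of methyl.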